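The compounds below may be only part of what the source reports. "The series", "measured", "known", "first", "only" and "open" are said of these compounds alone.

The measured compounds:
Compound 1 `COc1ccc2c(=O)c(/C=C/C(=O)Nc3cccc(Cl)c3)coc2c1` — in a functional assay on Huh-7 cells (Homo sapiens) for inhibition, read by MTT assay, with a stated time of 48 h (a higher number here means a weaker inhibitor, a lower number a stronger inhibitor), compound 1 reaches only the limit > 100000 nM.
Compound 2 `COc1ccc(NC(=O)/C=C/c2coc3cc(OC)ccc3c2=O)cc1` — in this assay compound 2 likewise reaches only the limit > 100000 nM.

Both results are limits of this assay and not numbers. Within the data shown here, the one measured step, a step that the two limits leave unreadable from compound 1 to compound 2, cannot be read because the limit of > 100000 nM in this assay, at which 2 of the 2 values shown sit, holds both of its ends; 4-methoxyphenyl in place of 3-chlorophenyl on an amide-type nitrogen thus leaves compound 2 standing where compound 1 stood, at the limit.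

Compound 3 `COc1ccc(CNC(=O)/C=C/c2coc3cc(OC)ccc3c2=O)cc1` differs from compound 2 by 4-methoxybenzyl in place of 4-methoxyphenyl on an amide-type nitrogen. No measured step in this assay bears a readable size, so nothing in the shown data sizes this change in either direction. The step implied by the estimate, a step that the limit leaves unreadable from compound 2 to compound 3, is therefore expected to be none beyond the scatter. Compound 3 is expected to give 150000 nM, within 40000 nM to 500000 nM, most probably reported again as a limit.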

Compound 3, half-maximal inhibitory concentration: 7570 nM
Beside the measured number, compound 3's estimate is 20-fold (1.30 log units) above it; measured number below the stated range.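

In this assay, the group on the amide-type nitrogen proves able to move the result off the limit: 4-methoxybenzyl in place of 4-methoxyphenyl gives an at least 13-fold lower number from compound 2 to compound 3 (1.12 log units; beyond the scatter), and 4-methoxybenzyl in place of 3-chlorophenyl gives an at least 13-fold lower number from compound 1 to compound 3 (1.12 log units; beyond the scatter). Compound 3 is the only one of the three with a number rather than a limit, so this position is not indifferent to the change, as the two earlier compounds could not show. Both steps give only a minimum size, because one end of each sits at a limit of the assay: the limit of > 100000 nM in this assay, at which 2 of the 3 values shown sit.

As far as these compounds go, whether a plain benzyl, a 3-chlorobenzyl or a longer chain such as 2-phenylethyl on this nitrogen would match compound 3 stays open. So does whether an amine or a carboxylic acid on the benzyl ring, in place of the methoxy group, would keep the number clear of the limit.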